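Pentylamino for chloro on a pyrazinecarboxamide core, toxicity outlook

The source may hold more compounds than are shown below. What is called first, only, known or untested is meant among the compounds shown, and "the series" means these compounds.

Measured compounds:
compound 1, `CCCCCCCCNc1cnc(C(=O)NCc2ccccc2)cn1`, 100000 nM
compound 2, `CCCCCCCCNc1cncc(C(=O)NCc2ccccc2)n1`, > 100000 nM (a limit of the assay)
compound 3, `O=C(NCc1ccccc1)c1cncc(Cl)n1`, "not determined" (no result reported)

In an ADME assay on HeLa cells (Homo sapiens) for cytotoxicity, read by microscopy, with a stated time of 6 days (on this read-out higher numbers stand for lower toxicity in this test and lower numbers for higher toxicity in this test), compound 1 gives 100000 nM. For compound 2 only a limit is reported, > 100000 nM, so no number is known for it. Compound 3 has no result at all in this assay, its entry reading "not determined" (no result reported), and of the three entries shown, one sits at the limit of > 100000 nM in this assay, at which 1 of the 3 values shown sits. Compound 3 therefore stands without a number, between a measured value and a limit.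

Compound 4, `CCCCCNc1cncc(C(=O)NCc2ccccc2)n1`, differs from compound 3 in one place: pentylamino in place of chloro on an aromatic carbon. Among the compounds with values here, no measured step joins these two, so no size can be read off. Compound 1 and compound 2, which carry a longer octylamino chain on the same kind of core, both show low toxicity on this read-out, and a step from compound 3 to compound 4 in this assay is expected to leave the result in that same region, with no change beyond the scatter.

Compound 4 is estimated at 100000 nM, with a range from 30000 nM to 200000 nM, and a limit rather than a number is expected to be a frequent outcome.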

Compound 4, minimum cytotoxic concentration: > 100000 nM
Compound 4: only a limit was reported; the forecaster's own chance of this, stated with the estimate: 55%; the middle value sits exactly at the limit.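

Within the data shown here, compound 2 and compound 4 are both reported only as limits of the assay, so no step between them can be read in this assay: the limit of > 100000 nM in this assay, at which 2 of the 4 values shown sit. The compounds shown leave open whether shortening the octylamino chain to pentylamino changes toxicity in this test at all.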